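The source may hold more compounds than are shown below. What is called first, only, known or untested is meant among the compounds shown, and "the series" means these compounds.

Working notes on a set of sulfonamides sharing one core. Compound 1 `COc1ccc(S(=O)(=O)Nc2cccc(I)c2)cc1N1CCNCC1` gives 0.501 nM in an assay on isolated protein for binding affinity to 5-hydroxytryptamine receptor 6 (Homo sapiens); on this read-out lower numbers stand for stronger inhibition and higher numbers for weaker inhibition. Compound 2 `COc1ccc(S(=O)(=O)Nc2ccc(Cl)c(Cl)c2)cc1N1CCNCC1` gives 2.51 nM, and compound 3 `COc1ccc(S(=O)(=O)Nc2cc(Cl)cc(Cl)c2Br)cc1N1CCNCC1` gives 3.16 nM, the highest of the three numbers; the step of a 1.3-fold higher number from compound 2 to compound 3 (0.10 log units; within the scatter) lies within the scatter, whereas a 5.0-fold higher number from compound 1 to compound 2 (0.70 log units; beyond the scatter) and a 6.3-fold higher number from compound 1 to compound 3 (0.80 log units; beyond the scatter) are modest steps beyond it. Compound 4 `COc1ccc(S(=O)(=O)Nc2cc(Br)cc(Br)c2Cl)cc1N1CCNCC1` is not yet measured. The change is 3,5-dibromo-2-chlorophenyl in place of 2-bromo-3,5-dichlorophenyl on a sulfonamide nitrogen. For the measured compounds named here, the only measured step that rearranges halogens on a ring already carrying several is a 1.3-fold higher number from compound 2 to compound 3 (0.10 log units; within the scatter), which stayed within the scatter; no measured step separates bromine from chlorine at the same place. In this assay no step beyond the scatter is therefore expected, namely a 1.0-fold higher number from compound 3 to compound 4 (0.01 log units; within the scatter). Compound 4 is estimated at 3.2 nM, within 1.6 nM to 6.3 nM.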

Compound 4, inhibition constant: 2.51 nM
Estimate against measurement, compound 4: 1.3-fold (0.11 log units) above; low and high end bracket the measured number.
By their numbers in this assay, from the lowest: compound 1; then compounds 2, 4 and 3 (each within the scatter of the next).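

In this assay, for the compounds shown here, 3,5-dibromo-2-chlorophenyl in place of 2-bromo-3,5-dichlorophenyl on a sulfonamide nitrogen gives a 1.3-fold lower number from compound 3 to compound 4 (0.10 log units; within the scatter), the first exchange of bromine and chlorine. The same group gives no change at the digits printed from compound 2 to compound 4 (within the scatter), while a 5.0-fold higher number from compound 1 to compound 4 (0.70 log units; beyond the scatter) keeps 3-iodophenyl apart from all three groups carrying several halogens. No evidence bears on why the numbers fall this way.

Open, from the compounds shown here alone, is whether a phenyl with a single bromine or chlorine in place of the iodine reads like compound 1 or like compound 4. Also open, going by these compounds, is how an amine or a carboxylic acid on this ring would read.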